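Removing a Methoxy from an Inactive Triazole Conjugate

A few compounds are considered here, and "the series" means these few. Any claim that something is new, unique, unknown or untested is made for them only; others in the source may bear on it.

Compound 1, `COc1ccc(-c2cn(C[C@H]3c4c(ccc(O)c4C)[C@@H]4CC[C@@]5(C)C[C@]43CC5=O)nn2)cc1`, was tested in a functional assay on SMMC-7721 cells (Homo sapiens) for cytotoxicity, read by MTT assay, with a stated time of 4 days; on this read-out lower numbers stand for stronger inhibition and higher numbers for weaker inhibition. In this assay compound 1 gives only a limit, > 20000 nM. Compound 2, `C=C1C[C@]23C[C@@]1(O)CC[C@H]2c1ccc(O)c(C)c1[C@@H]3Cn1cc(-c2ccc(OC)cc2)nn1`, likewise gives only a limit in this assay, > 20000 nM. Compound 1 thus stands at the limit of > 20000 nM in this assay, at which 2 of the 2 values shown sit. Compound 3, `Cc1c(O)ccc2c1[C@H](Cn1cc(-c3ccccc3)nn1)[C@@]13CC(=O)[C@@](C)(CC[C@@H]21)C3`, is not yet measured; it differs from compound 1 by hydrogen in place of methoxy on an aromatic carbon. For the measured compounds named here, no measured step between two numbers exists here, so the step that the limit leaves unreadable from compound 1 to compound 3 is expected to be none beyond the scatter, with no clear direction. Compound 3 is expected at 25000 nM, within 10000 nM to 60000 nM, most likely again reported only as a limit.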

Compound 3, half-maximal inhibitory concentration: > 20000 nM
Compound 3 gave a limit, no number (the forecaster's own chance of this, stated with the estimate: 80%); the middle value is on the limit's open side.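

For the compounds shown here, compound 1 and compound 3 both give only limits in this assay, so no step between them can be read. What the change from 4-methoxyphenyl to phenyl does to cytotoxicity stays open, as does any difference among the compounds shown: the limit of > 20000 nM in this assay, at which 3 of the 3 values shown sit.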